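Methyl for Chloro at the Edge of the Assay

This account rests on a few compounds, and the source may have more. Where it says the series, first, only, none or still open, it means among the compounds named here.

Compound 1 `Cc1cc(C)n2nc(SCc3cc(=O)c4cc(Cl)ccc4o3)nc2n1` was tested in a functional assay on LM7 cells (Homo sapiens) for cytotoxicity, read by MTT assay, with a stated time of 72 h; a lower number here means a stronger inhibitor, a higher number a weaker inhibitor. In this assay compound 1 gives > 25000 nM, which is a limit of the assay and not a number, sitting at the limit of > 25000 nM in this assay, at which 1 of the 2 values shown sits. The related compound 2 `Nc1nc(SCc2coc3ccccc3c2=O)n[nH]1` gives 16900 nM in this assay, a weak but measured value. Compound 3 `Cc1ccc2oc(CSc3nc4nc(C)cc(C)n4n3)cc(=O)c2c1` is derived from compound 1 by the change (methyl in place of chloro on an aromatic carbon). Within the data shown here, no measured step between two compounds speaks to this change, so no shift beyond the scatter is anticipated. Compound 3 is therefore expected near 30000 nM, within 12000 nM to 80000 nM, a step that the limit leaves unreadable from compound 1 to compound 3 that is an estimate only.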

Compound 3, half-maximal inhibitory concentration: > 25000 nM
Compound 3: a limit, no number; the forecaster's own chance of this, stated with the estimate: 65%; the middle value is on the limit's open side.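

Compound 1 and compound 3 both end at a limit of this assay, so no step can be read between them: the limit of > 25000 nM in this assay, at which 2 of the 3 values shown sit. The compounds shown leave open whether methyl in place of chloro on an aromatic carbon changes this read-out at all.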